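The source may report more compounds than this note shows. Statements on the series, on what has been measured and on what is new or still open speak of the compounds shown alone.

Compound 1 `CCCCCCCCNC1=CC(=O)C=C(C[C@]2(C)[C@@H](C)CC[C@]3(C)C(C)=CCC[C@@H]23)C1=O` carries an octylamino group on the quinone core; in a functional assay on NCI-H460 cells (Homo sapiens) for cytotoxicity, read by MTT assay, with a stated time of 72 h (a lower number here means a stronger inhibitor, a higher number a weaker inhibitor), compound 1 gives 35000 nM. Two smaller analogues frame it: compound 2 `CNC1=CC(=O)C(C(C)(C)C)=CC1=O` gives 58000 nM and compound 3 `CCCCCCCCNC1=CC(=O)C=C(C(C)(C)C)C1=O` gives 21000 nM in this assay. Compound 1 sits between the two, and its gap to either lies within the scatter, so no order among the three can be read. Compound 2 and compound 3 differ in chain length on the amine, and their two values also lie within the scatter of each other. Compound 4 `CCCCNC1=CC(=O)C=C(C[C@]2(C)[C@@H](C)CC[C@]3(C)C(C)=CCC[C@@H]23)C1=O` is compound 1 with a shortened chain: hydrogen in place of butyl on a saturated chain carbon, four bonds along the chain from an amine nitrogen. Since chain length appears to matter little here, the step from compound 1 to compound 4 is expected to be small, a 1.3-fold higher number from compound 1 to compound 4 (0.11 log units; within the scatter), within the scatter. Compound 4 is estimated at 45000 nM, with a range from 15000 nM to 130000 nM.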

Compound 4, half-maximal inhibitory concentration: 6000 nM
Estimate against measurement, compound 4: 7.5-fold (0.88 log units) above, outside the stated range (below it).
By their numbers in this assay, from the lowest: compound 4; then compounds 3, 1 and 2 (each within the scatter of the next, the first and the last beyond it).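

On the core of compound 1, the amine chain is not a silent position: shortening it gives a 5.8-fold lower number from compound 1 to compound 4 (0.77 log units; beyond the scatter) in this assay, a step beyond the scatter. For the compounds shown here, the earlier compounds offered no single-place pair, so this is the first reading of chain length on this core. Nothing measured here bears on why the shorter chain gives the lower number.

Going by these compounds alone, whether the number changes steadily with chain length remains open, since only two lengths stand on this core. A hexyl chain or a propyl chain on the same amine would test this.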